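Dropping a Methyl From a Saturated Ring Carbon

The compounds below may be only part of what the source reports. "The series", "measured", "known", "first", "only" and "open" are said of these compounds alone.

Three measured compounds share one core and differ only in the saturated ring attached to it. In a functional assay on CHO-K1 cells for antagonist activity at melanin-concentrating hormone receptor 1 (Homo sapiens), read by inositol phosphate accumulation (on this read-out lower numbers stand for stronger inhibition and higher numbers for weaker inhibition), compound 1 `Cc1nc(N2CCC(N3CCCC3)CC2)nc2ccc(NC(=O)C(C)Oc3ccc(Cl)cc3)cc12` gives 401 nM, compound 2 `CCC1(O)CCN(c2nc(C)c3cc(NC(=O)COc4ccc(Cl)cc4)ccc3n2)CC1` gives 384 nM, and compound 3 `Cc1nc(N2CCC(C)(O)CC2)nc2ccc(NC(=O)COc3ccc(Cl)cc3)cc12` gives 827 nM, the highest of the three numbers, so the weakest inhibitor here. Compound 4 `Cc1nc(N2CCC(O)CC2)nc2ccc(NC(=O)COc3ccc(Cl)cc3)cc12` is not yet measured; it differs from compound 3 by hydrogen in place of methyl on a saturated ring carbon, that is, 4-hydroxy-4-methylpiperidin-1-yl becoming 4-hydroxypiperidin-1-yl. One measured step resembles it: a 2.2-fold higher number from compound 2 to compound 3 (0.33 log units; beyond the scatter), where a methyl was likewise lost, though on a saturated chain carbon rather than a ring carbon. On that single comparison a further modest rise is expected, a 1.6-fold higher number from compound 3 to compound 4 (0.20 log units; within the scatter), with wide uncertainty. Compound 4 is therefore estimated at 1300 nM in this assay, within 500 nM to 3500 nM.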

Compound 4, half-maximal inhibitory concentration: 163 nM
The estimate for compound 4 lay 8.0-fold (0.90 log units) above the measured number; measured number outside the range, below it.
By their numbers in this assay, from the lowest: compound 4; then compounds 2 and 1 (each within the scatter of the next); then compound 3.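

In this assay, the methyl on this saturated ring carbon proves a liability, since replacing it with hydrogen gives a 5.1-fold lower number from compound 3 to compound 4 (0.71 log units; beyond the scatter) and the piperidine with no added group on that carbon is the strongest inhibitor of the set. Hydrogen in place of ethyl on the same carbon points the same way (a 2.4-fold lower number from compound 2 to compound 4 (0.37 log units; beyond the scatter)), yet group size alone does not set the order, as compound 2, with ethyl, gives a lower number than compound 3, with methyl. Nothing available explains this result.

Going by these compounds, whether a propyl chain or a fluorine on that carbon would fit this order remains open. So does the part played by the hydroxyl, which an amine or a methoxy in its place would test.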